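Aryl swap on a series at the assay limit

The source may report more compounds than this note shows. Statements on the series, on what has been measured and on what is new or still open speak of the compounds shown alone.

Three compounds share one core and differ only in the aryl group on the oxygen. In a functional assay on Jurkat cells (Homo sapiens) (on this read-out lower numbers stand for stronger inhibition and higher numbers for weaker inhibition), compound 1 `CC(C)[C@H](NC(=O)COc1cccc2ccccc12)C(=O)N[C@@H](CC(=O)O)C(=O)COc1ccc(C(N)=O)cc1` gives > 100000 nM as a limit. Compound 2 `CC(C)[C@H](NC(=O)COc1cccc2ccccc12)C(=O)N[C@@H](CC(=O)O)C(=O)COc1ccccc1[N+](=O)[O-]` gives > 100000 nM as a limit. Compound 3 `CC(C)[C@H](NC(=O)COc1cccc2ccccc12)C(=O)N[C@@H](CC(=O)O)C(=O)COc1ccc(F)c(F)c1` gives > 100000 nM as a limit and so has no numeric standing. Compound 4 `CC(C)[C@H](NC(=O)COc1cccc2ccccc12)C(=O)N[C@@H](CC(=O)O)C(=O)COc1c(F)ccc(F)c1F` carries this change: 2,3,6-trifluorophenyl in place of 3,4-difluorophenyl on an oxygen on a saturated carbon in the same setting. The nearest evidence is the step that the two limits leave unreadable from compound 1 to compound 3 and the step that the two limits leave unreadable from compound 2 to compound 3 along with the step that the two limits leave unreadable from compound 1 to compound 2 and none has a readable size. The series offers only the limit of > 100000 nM in this assay, at which 3 of the 3 values shown sit, as a guide. Stronger inhibition is tentatively expected, with a further limit quite possible. The expected change is an at least 5.0-fold lower number from compound 3 to compound 4 (0.69 log units; beyond the scatter) in this assay terms. Compound 4 is estimated at 20000 nM with an expected range from 1000 nM to 100000 nM in this read-out.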

Compound 4, half-maximal inhibitory concentration: 1200 nM
Estimate against measurement, compound 4: 17-fold (1.22 log units) above, and the stated range covers the measured number.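

In this assay, the aryl group on an oxygen on a saturated carbon can move the read-out: 2,3,6-trifluorophenyl gives an at least 83-fold lower number from compound 3 to compound 4 (1.92 log units; beyond the scatter), with an at least 83-fold lower number from compound 2 to compound 4 (1.92 log units; beyond the scatter) and an at least 83-fold lower number from compound 1 to compound 4 (1.92 log units; beyond the scatter). Going by these compounds alone, the steps among compound 1, compound 2 and compound 3 cannot be read, which leaves these three steps as the only readable evidence at this place. Only compound 4 has a numeric value, and the other compounds remain at the series limit: the limit of > 100000 nM in this assay, at which 3 of the 4 values shown sit.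

On these data alone, these steps are bounds, so their true sizes stay open. As far as these compounds go, it is also open whether the added fluorine or the substitution pattern carries the change, and a 2,6-difluorophenyl or 2,3,6-trichlorophenyl group would test this.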